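Replacing the dihydroindolyl group: expected effect on Vero cytotoxicity

The source may hold more compounds than are shown below. What is called first, only, known or untested is meant among the compounds shown, and "the series" means these compounds.

Two compounds sharing a common core have been examined in an ADME assay on Vero cells (Chlorocebus sabaeus) for cytotoxicity, with a stated time of 7 days; a higher number here means that more compound is tolerated, a lower number that less compound is tolerated. Compound 1 `O=C(c1cc2cc(C3CC3)ccc2[nH]1)N1CC(=O)N(Cc2ccccc2)[C@@H](CN2CCC(F)CC2)C1` gives 24500 nM in this assay. Compound 2 `COc1ccc2[nH]c(C(=O)N3CC(=O)N(Cc4ccccc4)[C@@H](N4CCc5ccccc54)C3)cc2c1` returns only a limit of the assay, > 100000 nM, so its value is not known as a number. Compound 2 therefore sits at the limit of > 100000 nM in this assay, at which 1 of the 2 values shown sits, while compound 1 stands at a measured figure. Within the data shown here, the two compounds differ in more than one place, so no single directed step between them can be drawn.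

Compound 3 `COc1ccc2[nH]c(C(=O)N3CC(=O)N(Cc4ccccc4)[C@@H](CN4CC5CC5C4)C3)cc2c1` has not yet been measured and is derived from compound 2 by one change: a group of 7 heavy atoms (6 carbon, 1 nitrogen; one three-membered non-aromatic ring of carbon only, one five-membered non-aromatic ring with 1 hetero atom) in place of a group of 9 heavy atoms (8 carbon, 1 nitrogen; one five-membered non-aromatic ring with 1 hetero atom, one six-membered aromatic ring of carbon only), on a saturated ring carbon. Because compound 2 sits at the limit of > 100000 nM in this assay, at which 1 of the 2 values shown sits, the step to compound 3 can only be flat or toward lower tolerance, and a modest step beyond the scatter in that direction is expected, an at least 2.2-fold lower number from compound 2 to compound 3 (0.34 log units; beyond the scatter). The half-maximal cytotoxic concentration of compound 3 is estimated at 45000 nM, with a range from 15000 nM to 100000 nM.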

Compound 3, half-maximal cytotoxic concentration: 13800 nM
For compound 3 the middle estimate is 3.3-fold (0.51 log units) above the measured one; measured number below the stated range.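

In this assay, the saturated ring carbon that bears the 2,3-dihydro-1H-indol-1-yl group proves sensitive to what it carries: the change to the new group, which has no common name, gives an at least 7.2-fold lower number from compound 2 to compound 3 (0.86 log units; beyond the scatter). Compound 3 gives 13800 nM, so this single change brings the read-out into the range where the assay returns a number. The true size of the step remains unknown and could be larger than printed, because its starting point is not a number: the limit of > 100000 nM in this assay, at which 1 of the 3 values shown sits.

The compounds shown leave open whether the step follows the loss of the six-membered aromatic ring or the arrival of the three-membered ring. They also leave open how a plain pyrrolidine or a morpholine would behave at this position.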